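Hydroxymethyl in place of 3-aminophenyl: cytotoxicity notes

This account rests on a few compounds, and the source may have more. Where it says the series, first, only, none or still open, it means among the compounds named here.

In an ADME assay on HEL cells (Homo sapiens), read by cell counting, with a stated time of 3 days (a lower number here means that less compound is tolerated, a higher number that more compound is tolerated), compound 1 `CCCCCCc1ccc(C#CC#Cc2cn([C@H]3C[C@H](O)[C@@H](CO)O3)c(=O)[nH]c2=O)cc1` gives 35000 nM and compound 3 `O=c1[nH]c(=O)n([C@H]2C[C@H](O)[C@@H](CO)O2)cc1C#CC#Cc1ccc(OC(F)(F)F)cc1` gives 55000 nM with no separation beyond the scatter. Compound 2 `Nc1cccc(C#CC#Cc2cn([C@H]3C[C@H](O)[C@@H](CO)O3)c(=O)[nH]c2=O)c1` stands at > 100000 nM and this is a limit of the assay, not a number.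

Going on to compound 4 `O=c1[nH]c(=O)n([C@H]2C[C@H](O)[C@@H](CO)O2)cc1C#CC#CCO` puts hydroxymethyl in place of 3-aminophenyl on a triple-bonded carbon and no measured step covers that exact change. Going by the values given here, the one measured step of a 1.6-fold higher number from compound 1 to compound 3 (0.20 log units; within the scatter) lies within the scatter and concerns a swap on an aromatic carbon, so it bears on this change only loosely. With compound 2 at > 100000 nM as a limit, no direction can be read from it, and no step beyond the scatter is expected in this assay for this change. The estimated step is a number no higher from compound 2 to compound 4 (the limit leaves the size open) on that reading. Compound 4 is expected at 100000 nM with an estimated range from 40000 nM to 200000 nM and may itself report only as a limit.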

Compound 4, half-maximal cytotoxic concentration: > 100000 nM
Compound 4 was reported as a limit (the forecaster's own chance of this, stated with the estimate: 60%); the middle value sits exactly at the limit.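

Compound 2 and compound 4 both report only as limits in this assay, so no step can be read between them: the limit of > 100000 nM in this assay, at which 2 of the 4 values shown sit.

The compounds shown leave open whether hydroxymethyl in place of 3-aminophenyl changes the half-maximal cytotoxic concentration at all, and in which direction.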